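The source may hold more compounds than are shown below. What is called first, only, known or untested is meant among the compounds shown, and "the series" means these compounds.

In an ADME assay on the whole organism (plasma) for pharmacokinetics, with Rattus norvegicus as the target, with a stated time of 6 h, at a dose of 10 mg/kg by the oral route (on this read-out lower numbers stand for lower exposure and higher numbers for higher exposure at the dose given), two compounds sharing one core have been measured. Compound 1 `Cc1nc(NC(C)C)nc(N[C@@H]2C[C@H](CO)[C@@H](O)[C@H]2O)c1-c1nc2ccccc2s1` gives 8420 ng.h/mL, while compound 2 `Cc1nc(NCc2ccccn2)nc(N[C@@H]2C[C@H](CO)[C@@H](O)[C@H]2O)c1-c1nc2ccccc2s1` gives 1630 ng.h/mL, the lower of the two numbers. Going by the values given here, the only measured step, a 5.2-fold lower number from compound 1 to compound 2 (0.71 log units; beyond the scatter), puts (pyridin-2-yl)methyl in place of isopropyl on a nitrogen on an aromatic ring.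

Compound 3 `Cc1nc(NCc2cccnc2)nc(N[C@@H]2C[C@H](CO)[C@@H](O)[C@H]2O)c1-c1nc2ccccc2s1` has the same atoms as compound 2, joined differently: pyridin-3-yl in place of pyridin-2-yl on a saturated chain carbon bound to a nitrogen on an aromatic ring. The exchange of pyridin-2-yl for pyridin-3-yl takes place on a saturated chain carbon bound to a nitrogen on an aromatic ring. Among the compounds with values here, no measured step makes this exchange, so the one step available bears on it only indirectly, and it replaced a different group. With no evidence for a direction, compound 3 is expected to stay near compound 2 at 1630 ng.h/mL, with no change beyond the scatter in this assay. The expected step is a 1.0-fold higher number from compound 2 to compound 3 (0.02 log units; within the scatter). For compound 3 the estimated value is 1700 ng.h/mL, with an expected range from 600 ng.h/mL to 5000 ng.h/mL.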

Compound 3, area under the concentration-time curve: 9.57 ng.h/mL
Compound 3: the middle estimate sits 180-fold (2.25 log units) above what was measured, and the stated range ends above it.
By their numbers in this assay, from the lowest: compound 3; then compound 2; then compound 1.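

In this assay, going by these compounds alone, the exchange of pyridin-2-yl for pyridin-3-yl on a saturated chain carbon bound to a nitrogen on an aromatic ring keeps the same atoms and the same counts of donors and acceptors, yet it brings a far larger change than the one step known before (a step of a 170-fold lower number from compound 2 to compound 3 (2.23 log units; beyond the scatter) against one of a 5.2-fold lower number from compound 1 to compound 2 (0.71 log units; beyond the scatter)). The exposure at this position therefore depends not only on the kind of group placed there but also on how the atoms of that group are joined, so the two pyridine isomers cannot be treated as interchangeable here. Measured against isopropyl, the (pyridin-3-yl)methyl group stands at the far end of the series (a step of an 880-fold lower number from compound 1 to compound 3 (2.94 log units; beyond the scatter)), which makes compound 3 the lowest of the three by steps that all lie beyond the scatter.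

Nothing available here explains why these two isomers part so sharply. Going by these compounds, it remains open where pyridin-4-yl, a plain phenyl or a longer chain carrying the pyridin-3-yl group would fall on this read-out, and whether any of them would return towards the number of compound 1 or stay as low as compound 3.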